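A few compounds are considered here, and "the series" means these few. Any claim that something is new, unique, unknown or untested is made for them only; others in the source may bear on it.

In an ADME assay on microsomes from liver (Homo sapiens) for metabolic stability, read by LC-MS, with a stated time of 10 min, tested at 0.5 uM (a lower number here means that less of the compound is left, a higher number that more of the compound is left), compound 1 `c1ccc2c(c1)CN[C@H](CN(CCCN1CCNCC1)[C@H]1CCCc3cccnc31)C2` gives 99%, and compound 2 `c1cnc2c(c1)CCC[C@@H]2N(CCCN1CCNCC1)Cc1nc2ccccc2s1` gives 50%, the lower of the two numbers. Compound 3 `c1cnc(CN(CCCN2CCNCC2)[C@H]2CCCc3cccnc32)nc1` departs from compound 2 by one group on a saturated chain carbon bound to an amine nitrogen: pyrimidin-2-yl in place of 1,3-benzothiazol-2-yl on a saturated chain carbon bound to an amine nitrogen. Going by the values given here, the only measured step at this place is a number 49 percentage points lower from compound 1 to compound 2 (beyond the scatter), with 1,3-benzothiazol-2-yl entering, so a partial recovery is expected on its removal, though pyrimidin-2-yl itself has no measurement yet. The expected change is moderate and upward, a number 20 percentage points higher from compound 2 to compound 3 (beyond the scatter). The estimated value for compound 3 is 70%, with an expected range of 50% to 90%.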

Compound 3, percent of the compound remaining: 100%
Compound 3: the middle estimate sits 30 percentage points below what was measured; measured number outside the range, above it.
By their numbers in this assay, from the lowest: compound 2; then compounds 1 and 3 (each within the scatter of the next).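

At this place, on a saturated chain carbon bound to an amine nitrogen, pyrimidin-2-yl in place of 1,3-benzothiazol-2-yl gives a number 50 percentage points higher from compound 2 to compound 3 (beyond the scatter) in this assay. Loss of 1,2,3,4-tetrahydroisoquinolin-3-yl alone therefore does not bring the low number: with pyrimidin-2-yl in its place the step is a number 1 percentage points higher from compound 1 to compound 3 (within the scatter), so among these three groups only 1,3-benzothiazol-2-yl stands apart. Nothing available explains this difference. From the compounds shown here alone, how phenyl or 1,3-thiazol-2-yl would read at this place stays open, so the low number cannot yet be tied to one part of the 1,3-benzothiazol-2-yl group.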